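The source may hold more compounds than are shown below. What is called first, only, known or untested is meant among the compounds shown, and "the series" means these compounds.

The compounds measured so far in an ADME assay on microsomes from liver (Homo sapiens) for metabolic stability, read by LC-MS, using NADPH, with a stated time of 45 min, tested at 0.5 uM; a lower number here means slower removal, a higher number faster removal of the compound:
- compound 1, `O=C(CCSc1nc2ccccc2o1)N1CCCC1`, gives 5.1 mL/min/g
- compound 2, `Cc1ccc2oc(SCCC(=O)N3CCCC3)nc2c1`, gives 9.3 mL/min/g
- compound 3, `O=C(CCSc1nc2cc(F)ccc2o1)N1CCCC1`, gives 5.2 mL/min/g

Compound 1 has the lowest of the three numbers, yet neither of the others stands apart from it: the step of a 1.0-fold higher number from compound 1 to compound 3 (0.01 log units; within the scatter) is hardly a change at all, and even the larger step of a 1.8-fold higher number from compound 1 to compound 2 (0.26 log units; within the scatter) stays within the scatter. Compound 4, `O=C(CCSc1nc2ccc(Cl)cc2o1)N1CCCC1`, is the next step from compound 1; the change is chloro in place of hydrogen on an aromatic carbon. Going by the values given here, two measured steps bear on it, as each also trades one hydrogen of the shared core for a new group: a 1.8-fold higher number from compound 1 to compound 2 (0.26 log units; within the scatter) and a 1.0-fold higher number from compound 1 to compound 3 (0.01 log units; within the scatter). Neither moved the number in this assay beyond the scatter, so for compound 4 no step beyond the scatter is expected in either direction, with only a slight lean upward because a 1.8-fold higher number from compound 1 to compound 2 (0.26 log units; within the scatter) was the larger of the two. The estimate for compound 4 is therefore 5.8 mL/min/g, expected to fall between 3 mL/min/g and 11 mL/min/g, a step of a 1.1-fold higher number from compound 1 to compound 4 (0.06 log units; within the scatter) that is expected to remain within the scatter.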

Compound 4, intrinsic clearance in a liver preparation (reported as CLH), per the amount of preparation that the assay uses: 6.6 mL/min/g
The estimate for compound 4 lay 1.1-fold (0.06 log units) below the measured number; low and high end bracket the measured number.
By their numbers in this assay, from the lowest: compounds 1, 3, 4 and 2 (each within the scatter of the next).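

Placed on an aromatic carbon that is meta to a fused ring and para to a fused ring, chloro brings a 1.3-fold higher number from compound 1 to compound 4 (0.11 log units; within the scatter) in this assay and so no shift beyond the scatter. Going by these compounds alone, this is a ring carbon other than the one carrying methyl in compound 2 and fluoro in compound 3, so the shared core now shows a second ring carbon where replacing hydrogen with a single new group stays within the scatter. All three replacements of hydrogen shown, in compound 2, compound 3 and compound 4, stay within the scatter, and no compound here goes against this.

On these data alone, whether an amine or a carboxylic acid on this carbon would move the number beyond the scatter remains open. Nothing shown here gives a measured reason for the size of these steps.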